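The compounds below may be only part of what the source reports. "The series", "measured", "known", "first", "only" and "open" are said of these compounds alone.

Measured compounds:

compound 1 `CS(=O)(=O)c1cccc(S(=O)(=O)c2ccc3c(c2)CCC[C@H]3CN)c1` with 3.98 nM
compound 2 `CNC[C@@H]1CCCc2cc(S(=O)(=O)c3cc[nH]c3)ccc21` with 0.159 nM
compound 3 `O=C(NC[C@@H]1CCCc2cc(S(=O)(=O)c3cccc(F)c3)ccc21)c1ccc[nH]1` with 5.01 nM

These three compounds were tested in an assay on isolated protein for displacement of a labelled ligand from 5-hydroxytryptamine receptor 6 (Homo sapiens); a lower number here means a stronger inhibitor, a higher number a weaker inhibitor. Compound 3 has the highest of the three numbers. Compound 1 is its nearest neighbour, and the gap between them lies within the usual scatter, so the two cannot be ordered. Compound 2 is furthest away, with a markedly lower number that lies well beyond the scatter.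

Compound 4 `COC(=O)NC[C@@H]1CCCc2cc(S(=O)(=O)c3cccc(F)c3)ccc21` has not yet been measured in this assay. It differs from compound 3 in one place: methoxy in place of 1H-pyrrol-2-yl on a carbonyl carbon

Going by the values given here, no measured pair in this set differs in the same way, so there is no directly comparable step to lean on. The shared core and the sulfone-linked ring of compound 3 are kept, and only the group on the carbonyl carbon is exchanged. On that basis compound 4 is expected to land close to compound 3, with at most a modest shift towards a higher number, a step of a 2.0-fold higher number from compound 3 to compound 4 (0.30 log units; within the scatter) that may not exceed the scatter. The estimate for compound 4 in this assay is 10 nM, with a likely range from 2.5 nM to 40 nM.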

Compound 4, inhibition constant: 1.59 nM
Compound 4: middle estimate off by 6.3-fold (0.80 log units), on the high side; measured number outside the range, below it.
By their numbers in this assay, from the lowest: compound 2; then compound 4; then compounds 1 and 3 (each within the scatter of the next).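

Going by these compounds alone, exchanging 1H-pyrrol-2-yl for methoxy on the carbonyl carbon gives a 3.2-fold lower number from compound 3 to compound 4 (0.50 log units; beyond the scatter) in this assay, the first comparison in which only this group changes. The number at this position therefore responds to the group on the carbonyl carbon, and losing the five-membered aromatic ring with its hydrogen-bond donor does not raise it. Nothing measured here accounts for the step.

Going by these compounds, it remains open whether a longer chain such as ethoxy or a plain methyl on the carbonyl carbon would lower the number further, and whether the step follows the loss of the ring, the loss of the donor or the entry of the methoxy oxygen. The step is also known only with the sulfone-linked ring that compound 3 and compound 4 share, so it may not carry over to other rings in that place.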